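The compounds below may be only part of what the source reports. "The series", "measured", "known", "first", "only" and "open" are said of these compounds alone.

Working notes on the lactone series.

Three compounds have been run in an ADME assay on PC-3 cells (Homo sapiens) for cytotoxicity, read by luminescence and ATP content, with a stated time of 48 h; on this read-out higher numbers stand for weaker inhibition and lower numbers for stronger inhibition. Compound 1, `O=C1OCC(c2ccc(C(F)(F)F)cc2)=C1c1c[nH]c2ccccc12`, gives a limit rather than a number in this assay, > 40000 nM. Compound 2, `O=C1OCC(c2ccc(C(F)(F)F)cc2)=C1c1ccncc1`, likewise returns only a limit, > 40000 nM. Compound 3, `COc1ccc(C2=C(c3ccc(OC)c(OC)c3)C(CO)OC2=O)cc1`, also comes back as a limit, > 40000 nM. Where compound 3 stands is therefore fixed only by this limit, and the two other values shown sit at the same point, so no step between any pair of these compounds can be measured; all three simply read as the limit described by the limit of > 40000 nM in this assay, at which 3 of the 3 values shown sit.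

The next compound, compound 4, `COc1ccc(C2=C(c3ccc(OC)c(OC)c3)C(CO)(CO)OC2=O)cc1`, is not yet measured. It differs from compound 3 by hydroxymethyl in place of hydrogen on a saturated ring carbon, so that the saturated ring carbon now carries two hydroxymethyl groups.

Among the measured compounds shown here, with no measured step to lean on, and the series so far showing nothing but limits, no direction can be assigned to the change; a step beyond the scatter in either direction is not expected. The step from compound 3 to compound 4 is estimated as a step that the limit leaves unreadable from compound 3 to compound 4. Compound 4 is accordingly expected to give 50000 nM, within a range of 20000 nM to 150000 nM, most probably reported again as a limit.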

Compound 4, half-maximal inhibitory concentration: > 40000 nM
Compound 4: no number, only a limit (the forecaster's own chance of this, stated with the estimate: 85%); the middle value lies beyond the limit too.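

Compound 3 and compound 4 both return only a limit in this assay, so no step between them can be read: the limit of > 40000 nM in this assay, at which 4 of the 4 values shown sit.

The compounds shown leave open how large the step for hydroxymethyl in place of hydrogen on the saturated ring carbon is, and whether any change to these structures gives a measurable value in this assay.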